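A Methylfuran in Place of a Trimethoxyphenyl in a Dienone

The source may hold more compounds than are shown below. What is called first, only, known or untested is meant among the compounds shown, and "the series" means these compounds.

Compound 1, `COc1ccc(/C=C/C(=O)C(=Cc2cc(OC)c(OC)c(OC)c2)C(=O)/C=C/c2ccc(OC)c(OC)c2)cc1OC`: 230 nM
Compound 2, `COc1cc(/C=C/C(=O)C(=Cc2cccc(OC)c2OC)C(=O)/C=C/c2ccc(O)c(OC)c2)ccc1O`: 420 nM

Both compounds were tested in a functional assay on A549 cells (Homo sapiens) for inhibition, read by sulforhodamine B assay, with a stated time of 48 h; a lower number here means a stronger inhibitor of growth, a higher number a weaker inhibitor of growth. Compound 1 gives the lowest of the two numbers, but the value of compound 2 lies within the usual scatter of that of compound 1, so the two cannot be ranked against each other. Going by the values given here, no two measured compounds differ in only one place, so no measured step is available to guide what a single change does to the read-out.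

Compound 3, `COc1ccc(/C=C/C(=O)C(=Cc2ccc(C)o2)C(=O)/C=C/c2ccc(OC)c(OC)c2)cc1OC`, differs from compound 1 in one place: 5-methylfuran-2-yl in place of 3,4,5-trimethoxyphenyl on a double-bonded chain carbon bound to a double-bonded chain carbon. The shared core of compound 1, with its two outer dimethoxyphenyl arms, is kept unchanged.

Among the compounds with values here, with no measured step of this kind to lean on, only a cautious expectation is possible. Compound 3 is expected to be a somewhat weaker growth inhibitor than compound 1, the expected step from compound 1 to compound 3 being a 2.0-fold higher number from compound 1 to compound 3 (0.29 log units; within the scatter), which would barely reach beyond the scatter. The estimate for compound 3 is 450 nM, expected to fall between 150 nM and 1400 nM.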

Compound 3, concentration for 50% growth inhibition: 1310 nM
Beside the measured number, compound 3's estimate is 2.9-fold (0.46 log units) below it; measured number inside the range.
By their numbers in this assay, from the lowest: compounds 1 and 2 (each within the scatter of the next); then compound 3.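

Going by these compounds alone, compound 3 provides the first single-change comparison here, and it shows that the group on this double-bonded chain carbon can alter the read-out in this assay: replacing 3,4,5-trimethoxyphenyl with 5-methylfuran-2-yl gives a 5.7-fold higher number from compound 1 to compound 3 (0.76 log units; beyond the scatter) and so weakens growth inhibition. The swap is not a small one, since a six-membered aromatic ring of carbon only, with 12 heavy atoms and 3 hydrogen-bond acceptors, gives way to a five-membered aromatic ring with 6 heavy atoms and 1 hydrogen-bond acceptor. Nothing measured here explains why the number rises.

Because ring, size and substituents all change in this single step, the compounds shown leave open which part of the swap accounts for the step, and this single pair cannot establish a wider rule for the position. An unsubstituted furan-2-yl, which differs from 5-methylfuran-2-yl only by the methyl group, and a phenyl ring carrying a single methoxy group or an amine would each separate these parts more finely.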